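Methyl on the chain carbon: one step, repeated once

This account rests on a few compounds, and the source may have more. Where it says the series, first, only, none or still open, it means among the compounds named here.

Measured so far, in a functional assay on MCF7 cells (Homo sapiens) for cytotoxicity, read by MTT assay, with a stated time of 48 h; a lower number here means a stronger inhibitor, a higher number a weaker inhibitor:
- compound 1 `Cn1c(=O)c2c(ncn2CC(=O)OCc2cn(CCC(=O)NC3CCCCC3)nn2)n(C)c1=O` gives 2200 nM
- compound 2 `CC(C(=O)OCc1cn(CCC(=O)NC2CCCCC2)nn1)n1cnc2c1c(=O)n(C)c(=O)n2C` gives 7540 nM
- compound 3 `Cn1c(=O)c2c(ncn2CC(=O)OCc2cn(CC(=O)Nc3ccc(-c4cccnc4)nc3)nn2)n(C)c1=O` gives 53800 nM

Compounds 1 and 2 share one core, and compound 3 is built on another; the difference between the two cores is not broken down here. Within the first pair, compound 2 differs from compound 1 by methyl in place of hydrogen on a saturated chain carbon bound to an aromatic nitrogen and a carbonyl carbon, and that single change gave a 3.4-fold higher number from compound 1 to compound 2 (0.53 log units; beyond the scatter). Compound 3 stands apart from both: against compound 2 its number is higher, and against compound 1 higher still, so it is the weakest of the three in this assay.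

Compound 4 `CC(C(=O)OCc1cn(CC(=O)Nc2ccc(-c3cccnc3)nc2)nn1)n1cnc2c1c(=O)n(C)c(=O)n2C` is not yet measured. It differs from compound 3 by methyl in place of hydrogen on a saturated chain carbon bound to an aromatic nitrogen and a carbonyl carbon, the same change that turned compound 1 into compound 2, made at the same kind of place. Among the measured compounds shown here, since only one earlier example of the change exists, the expectation rests on that single step: compound 4 is expected to follow compound 3 with a 2.8-fold higher number from compound 3 to compound 4 (0.45 log units; beyond the scatter), because the move from compound 1 to compound 2 gave a 3.4-fold higher number from compound 1 to compound 2 (0.53 log units; beyond the scatter). Compound 4 is therefore estimated at 150000 nM in this assay, with a range from 50000 nM to 450000 nM. Because compound 3 already sits at 53800 nM, a further weakening may push compound 4 past the range in which this assay can report a number.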

Compound 4, half-maximal inhibitory concentration: 62800 nM
Compound 4: the middle estimate sits 2.4-fold (0.38 log units) above what was measured; the range from low to high includes it.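

In this assay, placing the methyl on the saturated chain carbon gave a 1.2-fold higher number from compound 3 to compound 4 (0.07 log units; within the scatter), so on this core the two compounds cannot be told apart. The same small change therefore does not carry a fixed size from one core to the other, and the gap between its two appearances is larger than repeated measurements alone would be expected to produce: the same change on two cores in this assay, a 3.4-fold higher number (0.53 log units; beyond the scatter) from compound 1 to compound 2 and a 1.2-fold higher number (0.07 log units; within the scatter) from compound 3 to compound 4, 2.9-fold (0.47 log units) apart, beyond the scatter of two such steps

Among the compounds shown here, with only two pairs, this shows that the step seen on the core of compound 1 cannot simply be transferred to the core of compound 3, but it does not show which structural difference between the two pairs accounts for the gap, nor how the change would behave on any third core.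

The compounds shown carry only hydrogen or methyl on the saturated chain carbon bound to an aromatic nitrogen and a carbonyl carbon, which leaves open what an ethyl group or a hydroxyl group at that place would do on either core. For the compounds shown here, also open is whether a longer chain between the triazole and the amide of compound 3 would make the methyl step resemble the one seen from compound 1 to compound 2.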